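The compounds below may be only part of what the source reports. "The series", "measured", "known", "first", "only" and "open" are said of these compounds alone.

Series notes. Compound 3 `O=C(Nc1cccc(OCCc2ccccn2)c1)C1CCCN(C(=O)c2cc(C(F)(F)F)cc(C(F)(F)F)c2)C1` in an ADME assay on PC-3 cells (Homo sapiens) for cytotoxicity, read by WST assay, tested at 100 uM (a lower number here means less inhibition, a higher number more inhibition at the concentration tested (going by the name of the read-out)), gives 5%. Compound 1 `O=C(Nc1cccc(Oc2nccc(C(F)(F)F)c2Cl)c1)C1CCCN(C(=O)c2cc(C(F)(F)F)cc(C(F)(F)F)c2)C1` gives 0% and compound 2 `Cc1nc(-c2cccc(NC(=O)C3CCCN(C(=O)c4cc(C(F)(F)F)cc(C(F)(F)F)c4)C3)c2)cs1` gives 1%; the steps of a number 5 percentage points higher from compound 1 to compound 3 (within the scatter) and a number 4 percentage points higher from compound 2 to compound 3 (within the scatter) both lie within the scatter, so the three numbers cannot be ordered against each other. Compound 4 `O=C(Nc1cccc([N+](=O)[O-])c1)C1CCCN(C(=O)c2cc(C(F)(F)F)cc(C(F)(F)F)c2)C1` is the next member: nitro in place of 2-(pyridin-2-yl)ethoxy on an aromatic carbon. Among the compounds with values here, two measured steps bear on this position, a number 4 percentage points higher from compound 2 to compound 3 (within the scatter) and a number 5 percentage points higher from compound 1 to compound 3 (within the scatter), each within the scatter, and every replacement at this aromatic carbon so far has left the read-out flat near zero. No step beyond the scatter is therefore expected in this assay for compound 4, in either direction. Compound 4 is expected to give 3%, range 0% to 15%, a step of a number 2 percentage points lower from compound 3 to compound 4 (within the scatter) that is expected to stay within the scatter.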

Compound 4, a percentage reported as inhibition, at one concentration (the size of the read-out at that concentration, not a potency): 9%
The estimate for compound 4 lay 6 percentage points below the measured number, within the range that was stated.
By their numbers in this assay, from the lowest: compounds 1, 2, 3 and 4 (each within the scatter of the next).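

In this assay, nitro, a group with no ring, stays within the scatter of all three ring-bearing groups at this aromatic carbon: a number 4 percentage points higher from compound 3 to compound 4 (within the scatter), a number 8 percentage points higher from compound 2 to compound 4 (within the scatter) and a number 9 percentage points higher from compound 1 to compound 4 (within the scatter). Across these four compounds, then, a ring in this substituent is not needed for the read-out to stay at this level. Nothing available bears on why the read-out responds so little to this change.

From the compounds shown here alone, whether an amine or a carboxylic acid at this aromatic carbon would also stay within the scatter remains open. So does the effect of any change elsewhere on the shared core.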